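Cyclopropyl aryl replacement in the biphenyl amide series

The source may report more compounds than this note shows. Statements on the series, on what has been measured and on what is new or still open speak of the compounds shown alone.

Measured so far:
compound 1 `CC[C@H](C)[C@H](N)CN(C(=O)[C@@H]1C[C@H]1c1cccc(F)c1)c1ccc(-c2ccccc2)cc1` — 560 nM
compound 2 `CC[C@H](C)[C@H](N)CN(C(=O)[C@@H]1C[C@H]1c1c(F)cccc1F)c1ccc(-c2ccccc2)cc1` — 11000 nM

In a functional assay for agonist activity at G protein-coupled receptor 88 (Homo sapiens), read by HTRF and cAMP accumulation (a higher number here means that more compound is needed for the effect, a lower number that less compound is needed), compound 1 gives 560 nM and compound 2 gives 11000 nM; compound 2 thus stands highest of the two numbers, separated from compound 1 by a 20-fold higher number from compound 1 to compound 2 (1.29 log units; beyond the scatter). Compound 3 `CC[C@H](C)[C@H](N)CN(C(=O)[C@@H]1C[C@H]1c1ncccn1)c1ccc(-c2ccccc2)cc1` carries pyrimidin-2-yl in place of 2,6-difluorophenyl on a saturated ring carbon. Among the compounds with values here, no measured step covers an aryl-to-heteroaryl exchange at this position; the only step available, a 20-fold higher number from compound 1 to compound 2 (1.29 log units; beyond the scatter), shows that the group on this ring carbon can move the number greatly. Compound 3 is expected to land between the two measured values, which means a 4.4-fold lower number from compound 2 to compound 3 (0.64 log units; beyond the scatter). The estimate for compound 3 is 2500 nM, with a range from 400 nM to 15000 nM.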

Compound 3, half-maximal effective concentration: 130 nM
Compound 3: middle estimate off by 19-fold (1.28 log units), on the high side; the measured number lies below the stated range.
By their numbers in this assay, from the lowest: compound 3; then compound 1; then compound 2.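

Pyrimidin-2-yl on this saturated ring carbon gives an 85-fold lower number from compound 2 to compound 3 (1.93 log units; beyond the scatter) in this assay and also a 4.3-fold lower number from compound 1 to compound 3 (0.63 log units; beyond the scatter), so the lowest number so far comes from a ring with hetero atoms rather than a fluorinated phenyl. The position therefore accepts more than fluorinated phenyl groups, and the range across its three groups is wider than the fluorine change alone showed. Nothing at hand accounts for the drop. Still open, going by these compounds, is whether both ring nitrogens are needed, which pyridin-2-yl would address. Also open, on these data alone, is how an amine or a methoxy group on the pyrimidine ring would read.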